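The compounds below may be only part of what the source reports. "The series", "measured", "known", "first", "only" and "open" are said of these compounds alone.

Compound 1 `CC1=CC[C@H](C(C)(C)NC(=S)N/N=C/c2ccc(O)cc2)CC1` in a functional assay on NCI/ADR-RES cells (Homo sapiens) for inhibition, read by sulforhodamine B assay, with a stated time of 48 h (on this read-out higher numbers stand for weaker inhibition of growth and lower numbers for stronger inhibition of growth), gives > 100000 nM, which is a limit of the assay and not a number.
Compound 2 `COc1cc(/C=N/NC(=S)NC(C)(C)[C@H]2CC=C(C)CC2)ccc1O` in this assay gives > 100000 nM, again a limit of the assay.
Compound 3 `CC1=CC[C@H](C(C)(C)NC(=S)N/N=C(\C)c2ccccc2)CC1` in this assay gives > 100000 nM, again a limit of the assay.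

The change from compound 1 to compound 2 is methoxy in place of hydrogen on an aromatic carbon; its step, a step that the two limits leave unreadable from compound 1 to compound 2, cannot be sized because of the limit of > 100000 nM in this assay, at which 3 of the 3 values shown sit. Compound 4 `COc1ccc(/C(C)=N/NC(=S)NC(C)(C)[C@H]2CC=C(C)CC2)cc1` is not yet measured and differs from compound 3 by methoxy in place of hydrogen on an aromatic carbon, the same kind of change, but at a different place: in compound 2 the methoxy sits ortho to a hydroxy group and meta to a large group, whereas in compound 4 it sits para to a large group. The difference between the cores of compound 1 and compound 3 is not broken down here.

With every measured value sitting at the limit, the expectation for compound 4 rests only on (the limit of > 100000 nM in this assay, at which 3 of the 3 values shown sit), and the step that the limit leaves unreadable from compound 3 to compound 4 is expected to be unreadable in the same way. Compound 4 is expected to give 150000 nM, with a range from 40000 nM to 500000 nM, most likely again as a limit.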

Compound 4, concentration for total growth inhibition: > 100000 nM
Compound 4 ended at the assay's limit; the forecaster's own chance of this, stated with the estimate: 80%; the middle value is on the limit's open side.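

No new step can be read: the change from compound 3 to compound 4, phenyl to 4-methoxyphenyl, stays unsized in this assay because both values are limits of the assay: the limit of > 100000 nM in this assay, at which 4 of the 4 values shown sit.

The compounds shown leave open how far either methoxy change, or the difference between the cores of compound 1 and compound 3, alters growth inhibition.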